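This account rests on a few compounds, and the source may have more. Where it says the series, first, only, none or still open, it means among the compounds named here.

For the measured compounds named here, compound 2 `CCCCCCCCCCc1nc(N(C)C)c(C)c(C)c1O` stands at the top of the three numbers measured so far: in a functional assay on cells (Lymphocyte, Homo sapiens) for inhibition, read by flow cytometry, using a membrane potential dye, with a stated time of 16 h, tested at 500 nM (a lower number here means a weaker effect, a higher number a stronger effect of the compound at the concentration tested), compound 2 gives 90%. Compound 3 `CCCCCCCCCCCCCCCCc1c(C)c(N2CCC2)nc(C)c1O`, which carries a far longer saturated chain on its own core, gives 89% in this assay, a number within the scatter of compound 2. Compound 1 `Cc1c(N(C)C)nc(CCCCCCCCCCO)c(O)c1C` gives 50% in this assay, and the one step that joins two of these compounds in a single place, a number 40 percentage points higher from compound 1 to compound 2 (beyond the scatter), is large. Compound 4 `CCCCCCCCCCCCCCCCCCCc1nc(N(C)C)c(C)c(C)c1O` differs from compound 2 in one place: nonyl in place of hydrogen on a saturated chain carbon, ten or more bonds along the chain from an aromatic carbon. The step from compound 1 to compound 2 concerns the same region of the chain but a different change, so it speaks only indirectly; the pair of compound 2 and compound 3 shows that a much longer chain goes with a number of the same size. He therefore expects no step beyond the scatter in this assay, that is, a number 5 percentage points lower from compound 2 to compound 4 (within the scatter). For compound 4 he estimates 85%, with a range from 65% to 97%.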

Compound 4, a percentage reported as activity, at one concentration (the size of the read-out at that concentration, not a potency): 65%
Compound 4: the middle estimate sits 20 percentage points above what was measured; the measured number falls inside the stated range.
By their numbers in this assay, from the lowest: compound 1; then compound 4; then compounds 3 and 2 (each within the scatter of the next).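

In this assay, lengthening the chain at this position is not without consequence: nonyl in place of hydrogen on a saturated chain carbon, ten or more bonds along the chain from an aromatic carbon, gives a number 25 percentage points lower from compound 2 to compound 4 (beyond the scatter) on the shared core. The earlier step showed only that the read-out responds to removing hydroxy at this place, whereas this one shows that it also responds to adding a chain made of carbon alone. Nonyl in place of hydroxy still gives a number 15 percentage points higher from compound 1 to compound 4 (beyond the scatter), so compound 4 sits between the hydroxy compound and its shorter unsubstituted partner.

Going by these compounds, what a shorter chain, a branched chain, a carboxylic acid or an amine at this place would give remains open. Nothing available here accounts for either step.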